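Amide to Urea: Expecting the Next Step

The source may report more compounds than this note shows. Statements on the series, on what has been measured and on what is new or still open speak of the compounds shown alone.

Compound 1 `COc1cc(Cl)cc(-c2nn(-c3cccc(NC(=O)c4ccc(Cl)c(Cl)c4)c3)cc2-c2ccncc2)c1` gives 64.1% in a functional assay on U-251 cells (Homo sapiens) for inhibition, read by sulforhodamine B assay, with a stated time of 48 h, tested at 10 uM (a higher number here means a weaker effect of the compound at the concentration tested, a lower number a stronger effect), the higher of the two numbers measured here and so the weaker effect. Among the compounds with values here, compound 2 `COc1cc(Cl)cc(-c2nn(-c3cccc(NC(=O)Nc4ccc(Cl)c(C(F)(F)F)c4)c3)cc2-c2ccncc2)c1` gives -48.3% in this assay, and the one measured step, a number 112.4 percentage points lower from compound 1 to compound 2 (beyond the scatter), is large. Compound 3 `COc1cc(Cl)cc(-c2nn(-c3cccc(NC(=O)Nc4cccc(C(F)(F)F)c4)c3)cc2-c2ccncc2)c1` carries a closely related change: (3-(trifluoromethyl)phenyl)amino in place of 3,4-dichlorophenyl on a carbonyl carbon. That single step bears directly on it, because the change to compound 2 produced a number 112.4 percentage points lower from compound 1 to compound 2 (beyond the scatter), so a large drop is expected again, a number 69.1 percentage points lower from compound 1 to compound 3 (beyond the scatter). Compound 3 is therefore estimated to give -5%, within -50% to 45%.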

Compound 3, a percentage reported as activity, at one concentration (the size of the read-out at that concentration, not a potency): 4.59%
For compound 3 the middle estimate is 9.6 percentage points below the measured one, within the range that was stated.
By their numbers in this assay, from the lowest: compound 2; then compound 3; then compound 1.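

The urea with (3-(trifluoromethyl)phenyl)amino still falls well below the amide in this assay, with a number 59.5 percentage points lower from compound 1 to compound 3 (beyond the scatter) showing that the drop does not need the chloro of compound 2. That chloro still matters, as hydrogen in place of chloro on an aromatic carbon gives a number 52.9 percentage points higher from compound 2 to compound 3 (beyond the scatter). Nothing available here explains either step.

Still open, on these data alone, is how much of the drop comes from the added amide-type nitrogen and how much from the new ring substituents, as they change together. Also open, as far as these compounds go, is whether a methyl or a nitrile in place of that chloro would behave like chloro or like hydrogen.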